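The compounds below may be only part of what the source reports. "The series", "measured", "known", "first", "only" and "open" are said of these compounds alone.

For the measured compounds named here, compound 1 `O=C(Nc1cc(-c2ccccc2)nn1-c1ccccc1)c1ccccc1` gives 203 nM in a functional assay on cells for positive allosteric modulation of metabotropic glutamate receptor 5 (Rattus norvegicus), read by calcium flux (on this read-out lower numbers stand for an effect already at smaller amounts and higher numbers for an effect only at larger amounts of compound), and stands highest of the two numbers measured so far; its nearest neighbour is compound 2 `O=C(Nc1cc(-c2ccccc2)nn1-c1ccccc1)c1cccc([N+](=O)[O-])c1`, which gives 39 nM in this assay, so that a 5.2-fold lower number from compound 1 to compound 2 (0.72 log units; beyond the scatter). Compound 3 `COc1cccc(-c2cc(NC(=O)c3ccccc3)n(-c3ccccc3)n2)c1` is the next variation on compound 1: methoxy in place of hydrogen on an aromatic carbon. Going by the values given here, the only measured step that bears on it is the nitro step, which lowered the number modestly; no methoxy analogue has been measured, so its size cannot be read directly, and a smaller move in the same direction, or none beyond the scatter, is expected. For compound 3 the expected value in this assay is 150 nM, within 60 nM to 400 nM, meaning an expected 1.4-fold lower number from compound 1 to compound 3 (0.13 log units; within the scatter).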

Compound 3, half-maximal effective concentration: 600 nM
The estimate for compound 3 lay 4.0-fold (0.60 log units) below the measured number; measured number above the stated range.
By their numbers in this assay, from the lowest: compound 2; then compound 1; then compound 3.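

In this assay, phenyl to 3-methoxyphenyl gives a 3.0-fold higher number from compound 1 to compound 3 (0.47 log units; beyond the scatter), so an added group on the core of compound 1 does not always lower the number. The nitro change elsewhere on that core gave a 5.2-fold lower number from compound 1 to compound 2 (0.72 log units; beyond the scatter), and the two single changes therefore move in opposite directions. No measurement at hand accounts for the rise with methoxy.

Open, going by these compounds, is whether a hydroxyl or an amine on the same aromatic carbon would raise the number as methoxy does. Also open, on these data alone, is how methoxy would behave at the carbon carrying nitro in compound 2.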